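Removing one trifluoromethyl from a diaryl ether cytotoxicity series

A few compounds are considered here, and "the series" means these few. Any claim that something is new, unique, unknown or untested is made for them only; others in the source may bear on it.

Compound 2 `Cc1cn(C2CCN(Cc3cccc(Oc4cc(C(F)(F)F)cc(C(F)(F)F)c4)c3)CC2)c(=O)[nH]c1=O` carries two trifluoromethyl groups on the outer aromatic ring of a diaryl ether, and in an ADME assay on MRC5 cells (Homo sapiens) for cytotoxicity, read by fluorescence and resazurin assay, with a stated time of 3 days (a lower number here means a stronger inhibitor, a higher number a weaker inhibitor), compound 2 has "not determined" (no result reported). Its closest measured relatives are compound 1 `Cc1ccc(Oc2cccc(CN3CCC(n4cc(C)c(=O)[nH]c4=O)CC3)c2)cc1` and compound 3 `Cc1cn(C2CCN(Cc3cccc(Oc4cc(F)cc(F)c4)c3)CC2)c(=O)[nH]c1=O`. In this assay compound 1 gives > 64000 nM, which is a limit of the assay and not a number. In this assay compound 3 likewise gives > 64000 nM, again a limit rather than a number. For the measured compounds named here, the only computed step, a step that the two limits leave unreadable from compound 1 to compound 3, therefore cannot be read; both ends rest on (the limit of > 64000 nM in this assay, at which 2 of the 3 values shown sit).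

Compound 4 `Cc1cn(C2CCN(Cc3cccc(Oc4cccc(C(F)(F)F)c4)c3)CC2)c(=O)[nH]c1=O` is the compound still to be measured. It differs from compound 2 by hydrogen in place of trifluoromethyl on an aromatic carbon.

Going by the values given here, no measured step bears directly on this change. What the two limits do show is that two close relatives of compound 4 stayed outside the measurable window. Compound 4, with one trifluoromethyl fewer than compound 2, is expected to behave the same way and to reach no number in this assay. Compound 4 is expected at 100000 nM, in a range from 30000 nM to 300000 nM.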

Compound 4, half-maximal inhibitory concentration: 12400 nM
Compound 4: the middle estimate sits 8.1-fold (0.91 log units) above what was measured, outside the stated range (below it).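

Compound 4 is the only one of the compounds shown that gives a number in this assay, so what sits on the outer aromatic ring of the diaryl ether can move this read-out into the measurable window. Placing 3-(trifluoromethyl)phenyl on the ether oxygen in place of 3,5-difluorophenyl gives an at least 5.1-fold lower number from compound 3 to compound 4 (0.71 log units; beyond the scatter), and placing it there in place of 4-methylphenyl gives an at least 5.1-fold lower number from compound 1 to compound 4 (0.71 log units; beyond the scatter), so in both comparisons the lower number marks a stronger effect on the cells. Compound 1 and compound 3 each rest on a limit of the assay and not on a number: the limit of > 64000 nM in this assay, at which 2 of the 4 values shown sit.

Going by these compounds, with compound 2 at "not determined" (no result reported), the size of the change from two trifluoromethyl groups to one cannot be read, so the role of the second group stays open. Also open, on these data alone, is whether the trifluoromethyl group itself is needed for a number here, or whether a nitrile, a methoxy group or an amine in its place on the outer ring of compound 4 would give a similar value.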